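Dibenzyl Urea Aryl Variation in Sterol Acyltransferase Inhibition

The source may hold more compounds than are shown below. What is called first, only, known or untested is meant among the compounds shown, and "the series" means these compounds.

Compound 1 `CCCCCCN(CCCCCC)C(=O)Nc1ccc(C)cc1C`: 0.11 ug/mL
Compound 2 `CCCCCCCCCCN(CCCCCCCCCC)C(=O)Nc1ccc(C)cc1C`: 0.28 ug/mL
Compound 3 `Cc1cc(C)c(NC(=O)N(Cc2ccccc2)Cc2ccccc2)c(C)c1`: 1.34 ug/mL

Three ureas have been tested in an assay on isolated protein for inhibition of sterol O-acyltransferase 1 (Rattus norvegicus); on this read-out lower numbers stand for stronger inhibition and higher numbers for weaker inhibition. Compound 1 gives 0.11 ug/mL, compound 2 gives 0.28 ug/mL, and compound 3 gives 1.34 ug/mL. Compound 3 therefore stands at the highest number of the three; its nearest neighbour is compound 2, while compound 1 lies furthest from it, both gaps beyond the scatter.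

Compound 4 `Cc1c(Cl)cccc1NC(=O)N(Cc1ccccc1)Cc1ccccc1` keeps the dibenzyl urea portion of compound 3 and carries one change: 3-chloro-2-methylphenyl in place of 2,4,6-trimethylphenyl on an amide-type nitrogen. Among the measured compounds shown here, no measured pair in this set shows the effect of such an aryl exchange, so the size of the step cannot be read from the data. In this assay the step from compound 3 to compound 4 is expected to be small, a 1.1-fold higher number from compound 3 to compound 4 (0.05 log units; within the scatter), with no clear direction beyond the scatter. Compound 4 is estimated at 1.5 ug/mL, within a range from 0.5 ug/mL to 4.5 ug/mL.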

Compound 4, half-maximal inhibitory concentration: 3.06 ug/mL
Beside the measured number, compound 4's estimate is 2.0-fold (0.31 log units) below it, and the stated range covers the measured number.
By their numbers in this assay, from the lowest: compound 1; then compound 2; then compound 3; then compound 4.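

With the dibenzyl urea portion held constant, the aryl group on the amide-type nitrogen proves able to shift the result in this assay: 3-chloro-2-methylphenyl in place of 2,4,6-trimethylphenyl gives a 2.3-fold higher number from compound 3 to compound 4 (0.36 log units; beyond the scatter) in a modest step beyond the scatter. Among the compounds shown here, this is the first comparison in the set that differs in one place, and 2,4,6-trimethylphenyl holds the lower number of the two. Nothing measured here accounts for the step. From the compounds shown here alone, whether a methoxy or fluoro substituent on this aryl ring would lower or raise the number remains open. So does whether the same aryl exchange would give a similar step with the two hexyl chains of compound 1.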